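This account rests on a few compounds, and the source may have more. Where it says the series, first, only, none or still open, it means among the compounds named here.

The series shares the core of compound 1 `CCc1nc(N)nc(N)c1-c1ccc(NCc2cc(F)c(S(C)(=O)=O)c(F)c2)cc1` and varies the group on the saturated chain carbon bound to a nitrogen on an aromatic ring. In an in vitro assay on CHOK cells for displacement of a labelled ligand from growth hormone secretagogue receptor type 1 (Homo sapiens) (on this read-out higher numbers stand for weaker inhibition and lower numbers for stronger inhibition), compound 1 gives 2.4 nM. Among the compounds with values here, compound 2 `CCc1nc(N)nc(N)c1-c1ccc(NCc2ccc([N+](=O)[O-])cc2)cc1` carries 4-nitrophenyl at that position, and in this assay compound 2 gives 11 nM, the highest of the two numbers measured so far; its nearest neighbour is compound 1, whose lower number lies beyond the scatter. Compound 3 `CCc1nc(N)nc(N)c1-c1ccc(NCc2ccnc(Cl)c2)cc1` is not yet measured and differs from compound 2 in one place: 2-chloropyridin-4-yl in place of 4-nitrophenyl on a saturated chain carbon bound to a nitrogen on an aromatic ring. Within the data shown here, no step between measured compounds covers an exchange of this kind, so the expectation rests on compound 2 alone. The step of a 1.4-fold higher number from compound 2 to compound 3 (0.13 log units; within the scatter) is expected to stay within the scatter, if anything toward a slightly higher number. For compound 3 in this assay the estimate is 15 nM, in the range 5 nM to 45 nM.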

Compound 3, half-maximal inhibitory concentration: 110 nM
The estimate for compound 3 lay 7.3-fold (0.87 log units) below the measured number; the whole stated range lies below it.
By their numbers in this assay, from the lowest: compound 1; then compound 2; then compound 3.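

At the saturated chain carbon bound to a nitrogen on an aromatic ring, the group is not freely exchangeable in this assay: 2-chloropyridin-4-yl in place of 4-nitrophenyl gives a 10-fold higher number from compound 2 to compound 3 (1.00 log units; beyond the scatter) as the first single-place step read in the series. The exchange alters several things at once, with a hetero atom entering the ring, chlorine entering and the nitro group leaving, so this one step cannot assign the change in number to any one of them. Nothing available accounts for the size of the step.

Still open, on these data alone, is whether the step follows the ring nitrogen or the chlorine, a question that 4-chlorophenyl and unsubstituted pyridin-4-yl at this position would separate. Also open, as far as these compounds go, is how the position responds to a group without an aromatic ring, such as a carboxylic acid or an amine on a longer chain.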